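Second fluoro on the phenol ring of compound 1

This account rests on a few compounds, and the source may have more. Where it says the series, first, only, none or still open, it means among the compounds named here.

Measured so far in an assay on microsomes from placenta for inhibition of 17-beta-hydroxysteroid dehydrogenase type 2 (Homo sapiens), read by HPLC, in the presence of a further agent that is not named here; on this read-out higher numbers stand for weaker inhibition and lower numbers for stronger inhibition:
compound 1, `Cc1cc(-c2ccc(C(=O)c3cc(F)cc(O)c3C)s2)cc(C)c1O`: 76 nM
compound 2, `Cc1cc(-c2ccc(C(=O)c3cccc(O)c3C)s2)cc(C)c1O`: 239 nM
Not yet measured: compound 3, `Cc1cc(-c2ccc(C(=O)c3cc(F)c(F)c(O)c3C)s2)cc(C)c1O`

In this assay compound 1 gives 76 nM, the lowest of the two numbers in hand; its nearest neighbour is compound 2 with 239 nM. Within the data shown here, the single measured step, a 3.1-fold higher number from compound 1 to compound 2 (0.50 log units; beyond the scatter), is modest but runs beyond the scatter and consists of hydrogen in place of fluoro on an aromatic carbon. Compound 3 carries fluoro in place of hydrogen on an aromatic carbon, placed ortho to a fluoro group and ortho to a hydroxy group, meta to a methyl group and para to a large group. Among the measured compounds shown here, the measured step bears on this only indirectly: it shows that taking away the fluoro of compound 1 weakens inhibition, whereas compound 3 keeps that fluoro and adds a second one at a different aromatic carbon, a change for which no measured pair exists. A small shift toward stronger inhibition, or none beyond the scatter, is therefore expected, the lean toward a gain resting on compound 1 because a 3.1-fold higher number from compound 1 to compound 2 (0.50 log units; beyond the scatter) shows the existing fluoro to matter. For compound 3 the expected value in this assay is 55 nM, within 20 nM to 150 nM. This estimate corresponds to an expected step of a 1.4-fold lower number from compound 1 to compound 3 (0.14 log units; within the scatter).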

Compound 3, half-maximal inhibitory concentration in the 17-beta-hydroxysteroid dehydrogenase type 2 assay: 159 nM
The estimate for compound 3 lay 2.9-fold (0.46 log units) below the measured number, and the stated range ends below it.
By their numbers in the 17-beta-hydroxysteroid dehydrogenase type 2 assay, from the lowest: compound 1; then compounds 3 and 2 (each within the scatter of the next).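

In the 17-beta-hydroxysteroid dehydrogenase type 2 assay, this position, ortho to a hydroxy group and para to a large group, gave a modest loss when fluoro replaced hydrogen (a 2.1-fold higher number from compound 1 to compound 3 (0.32 log units; beyond the scatter)). The benefit tied to the fluoro already in compound 1 (a 3.1-fold higher number from compound 1 to compound 2 (0.50 log units; beyond the scatter)) therefore does not carry over to a second fluoro at this carbon, and within this short series the same kind of change runs in opposite directions at two places on the ring. The added fluoro also comes with a loss in a physicochemical assay for solubility, in phosphate buffer, with a stated time of 24 h, at pH 7.2 (on this read-out higher numbers stand for higher solubility and lower numbers for lower solubility), so compound 3 falls behind compound 1 on both read-outs: the measured solubility of compound 1, 100000 nM, and of compound 3, 15000 nM, a 6.7-fold lower number (0.82 log units; beyond the scatter). In the physicochemical assay compound 1 gives 100000 nM and compound 3 gives 15000 nM.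

From the compounds shown here alone, it remains open whether the loss in inhibition and the drop in solubility belong to fluoro itself or to any group at this carbon, which a chloro, a methoxy or an amine at the same place would help to separate. Also open, going by these compounds, is whether a carboxylic acid elsewhere on the core of compound 1 could raise solubility while keeping the inhibition of compound 1.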